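The source may hold more compounds than are shown below. What is called first, only, known or untested is meant among the compounds shown, and "the series" means these compounds.

Of the compounds shown here, two sharing one core have been tested in a functional assay on MCF7 cells (Homo sapiens) for cytotoxicity, read by MTT assay, with a stated time of 48 h; on this read-out higher numbers stand for weaker inhibition and lower numbers for stronger inhibition. Compound 1 `CCN(CC)c1ccc2cc(C(=O)c3ccc(N4CCN(C(=O)CN5CCN(Cc6ccc(/C=C/C(=O)OC)cc6)CC5)CC4)cc3)oc2c1` carries a 4-(2-(methoxycarbonyl)ethenyl)phenyl group on a saturated chain carbon bound to an amine nitrogen in a ring, and in this assay compound 1 gives 8730 nM. Compound 2 `CCOC(=O)CN1CCN(CC(=O)N2CCN(c3ccc(C(=O)c4cc5ccc(N(CC)CC)cc5o4)cc3)CC2)CC1` carries ethoxycarbonyl at that place instead. For compound 2 this assay reports only a limit, > 40000 nM, so where compound 2 truly stands is not pinned down. The measured step of an at least 4.5-fold higher number from compound 1 to compound 2 (0.66 log units; beyond the scatter) therefore rests on a limit (the limit of > 40000 nM in this assay, at which 1 of the 2 values shown sits).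

Compound 3 `CCN(CC)c1ccc2cc(C(=O)c3ccc(N4CCN(C(=O)CN5CCN(CC(C)=O)CC5)CC4)cc3)oc2c1` differs from compound 2 by methyl in place of ethoxy on a carbonyl carbon, a change reading ethoxycarbonyl to acetyl. Among the measured compounds shown here, no measured step touches this carbonyl carbon: the only step available alters a different group and itself ends at a limit, so it gives no direct guide. With the carbonyl kept and only the ethoxy removed, compound 3 is expected to remain close to compound 2, and the estimated step that the limit leaves unreadable from compound 2 to compound 3 is expected to be small. Compound 3 is estimated at 45000 nM, within a range from 12000 nM to 150000 nM, most likely again reported as a limit.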

Compound 3, half-maximal inhibitory concentration: 11000 nM
Compound 3: middle estimate off by 4.1-fold (0.61 log units), on the high side; measured number outside the range, below it.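

At this carbonyl carbon the group matters: in this assay, putting methyl in place of ethoxy gives an at least 3.6-fold lower number from compound 2 to compound 3 (0.56 log units; beyond the scatter), so a change of only a few atoms moves the read-out beyond the usual scatter toward stronger inhibition. The new compound also shows that the large group of compound 1 is not needed to reach this level, since acetyl in place of 4-(2-(methoxycarbonyl)ethenyl)phenyl gives a 1.3-fold higher number from compound 1 to compound 3 (0.10 log units; within the scatter), and these two very different groups cannot be told apart in this read-out, while ethoxycarbonyl stands apart from both. On these data alone, the full size of the step from ethoxycarbonyl to acetyl stays unknown, and only its minimum can be stated, because compound 2 is known only through a limit and not through a number: the limit of > 40000 nM in this assay, at which 1 of the 3 values shown sits.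

As far as these compounds go, it remains open whether methoxy or a hydroxy group on this carbonyl carbon, which would give a methyl ester or a carboxylic acid, would read like ethoxycarbonyl or like acetyl. From the compounds shown here alone, it is equally open whether an amide or a ketone with a longer chain at this place would keep the level of compound 3.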